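The compounds below may be only part of what the source reports. "The series", "measured", "known", "first", "only" and "open" are said of these compounds alone.

Compound 1 `O=C(O)CCc1ccc2[nH]c(-c3ccccc3OC(F)(F)F)cc2c1`: 1020 nM
Compound 2 `Cn1c(-c2cccc(Cl)c2)cc2cc(CCC(=O)O)ccc21`: > 10000 nM

In a functional assay on CHO cells for agonist activity at Free fatty acid receptor 1 (Homo sapiens), read by a luciferase reporter, with a stated time of 24 h (on this read-out higher numbers stand for an effect only at larger amounts of compound and lower numbers for an effect already at smaller amounts), compound 1 gives 1020 nM. For compound 2 the assay reports only a limit, > 10000 nM, so compound 2 stands at the limit of > 10000 nM in this assay, at which 1 of the 2 values shown sits, and its true number is not known. Compound 3 `Cn1c(-c2ccccc2Br)cc2cc(CCC(=O)O)ccc21` differs from compound 2 in one place: 2-bromophenyl in place of 3-chlorophenyl on an aromatic carbon. Among the compounds with values here, no measured pair shows this change, so its size is open; some gain is expected, though compound 2 starts from a limit. The expected step is an at least 1.2-fold lower number from compound 2 to compound 3 (0.09 log units; that floor lies within the scatter). Compound 3 is estimated at 8000 nM, with a range from 2000 nM to 30000 nM.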

Compound 3, half-maximal effective concentration: > 10000 nM
Compound 3 gave a limit, no number; the forecaster's own chance of this, stated with the estimate: 55%; at least 1.2-fold (0.09 log units) between middle value and limit.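

Compound 3 also gives only a limit, > 10000 nM, so no step can be read between compound 2 and compound 3. The compounds shown leave open whether 2-bromophenyl and 3-chlorophenyl differ at all in this assay.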